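Azole isomer swap on the benzyl arm of compound 3

This account rests on a few compounds, and the source may have more. Where it says the series, first, only, none or still open, it means among the compounds named here.

Compound 3 `Cc1cc(C)c(NC(=O)N(Cc2ccc(-n3cccn3)cc2)C2CCCCCC2)c(C)c1` is held at a limit in a functional assay on a cell-free system (plasma) with sterol O-acyltransferase, Soat (Rattus norvegicus) as the target; a lower number here means that less compound is needed, a higher number that more compound is needed for the effect: for compound 3 only the limit > 1 mg/kg is known, not a number. Compound 1 `Cc1cc(C)c(NC(=O)N(Cc2ccc(N3CCN(C)CC3)cc2)C2CCCCCC2)c(C)c1` likewise gives only the limit > 1 mg/kg. Compound 2 `O=C(Nc1c(F)cc(F)cc1F)N(Cc1ccc(F)cc1)Cc1cccc(-c2cc[nH]n2)c1` sits at the opposite limit, < 0.32 mg/kg. Within the data shown here, the single one-point step recorded so far, a step that the two limits leave unreadable from compound 1 to compound 3, runs between two limits and its size cannot be read. the limit of > 1 mg/kg in this assay, at which 2 of the 3 values shown sit, and the limit of < 0.32 mg/kg in this assay, at which 1 of the 3 values shown sits, describe how the three values are spread: two at one limit, one at the other, with no graded numbers in between.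

Compound 4 `Cc1cc(C)c(NC(=O)N(Cc2ccc(-n3ccnc3)cc2)C2CCCCCC2)c(C)c1` differs from compound 3 by 1H-imidazol-1-yl in place of 1H-pyrazol-1-yl on an aromatic carbon; the two have the same atoms, joined differently. Among the measured compounds shown here, no measured step bears on this exchange of one azole for the other. For the measured compounds named here, the only recorded step, a step that the two limits leave unreadable from compound 1 to compound 3, is unreadable, and compound 2 shares no one-point change with compound 3 or compound 4. With nothing to indicate a direction, the expected step is a step that the limit leaves unreadable from compound 3 to compound 4, within the usual scatter. Compound 4 is therefore estimated at 1.5 mg/kg, within 0.5 mg/kg to 5 mg/kg, and the most likely outcome is again only a limit rather than a number.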

Compound 4, dose for half-maximal effect: > 1 mg/kg
Compound 4: no number, only a limit (the forecaster's own chance of this, stated with the estimate: 70%); the middle value does not contradict the limit.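

In this assay compound 4 gives > 1 mg/kg, a limit and not a number, and the steps to it from compound 1 and compound 3 cannot be read. The compounds shown leave open how 1H-imidazol-1-yl, 1H-pyrazol-1-yl and 4-methylpiperazin-1-yl compare on the shared core of compound 1, compound 3 and compound 4.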